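The source may report more compounds than this note shows. Statements on the series, on what has been measured and on what is new or still open speak of the compounds shown alone.

Three compounds have been measured in an assay on isolated protein for inhibition of Amine oxidase [flavin-containing] A (Homo sapiens), read by fluorescence and Amplex Red, with a stated time of 30 min, tested at 10 uM; on this read-out higher numbers stand for a stronger effect at the one concentration tested and lower numbers for a weaker effect:

Compound 1, `CCCCNc1nnc(SCC(=O)N(Cc2cccc([N+](=O)[O-])c2)c2ccc(F)cc2)s1`: 76%
Compound 2, `CCCNc1nnc(SCC(=O)N(Cc2cccc([N+](=O)[O-])c2)c2ccc(F)cc2)s1`: 78.3%
Compound 3, `C=CCNc1nnc(SCC(=O)N(Cc2cccc([N+](=O)[O-])c2)c2ccc(F)cc2)s1`: 75.2%

Compound 3 gives the smallest of the three numbers, but its gaps to the others are small: a number 0.8 percentage points lower from compound 1 to compound 3 (within the scatter) and a number 3.1 percentage points lower from compound 2 to compound 3 (within the scatter). On these numbers the three compounds cannot be told apart.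

Compound 4, `CCNc1nnc(SCC(=O)N(Cc2cccc([N+](=O)[O-])c2)c2ccc(F)cc2)s1`, differs from compound 3 by methyl in place of vinyl on a saturated chain carbon bound to a nitrogen on an aromatic ring. Among the measured compounds shown here, the steps that bear on this change are those at the same place on the chain, a number 3.1 percentage points lower from compound 2 to compound 3 (within the scatter) and a number 0.8 percentage points lower from compound 1 to compound 3 (within the scatter), and the shortening one bond further along, a number 2.3 percentage points higher from compound 1 to compound 2 (within the scatter); all stayed within the scatter. Compound 4 is therefore expected to show no step beyond the scatter, a number 0.8 percentage points higher from compound 3 to compound 4 (within the scatter). For compound 4 the estimate is 76%, in the range 66% to 86%.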

Compound 4, a percentage reported as inhibition, at one concentration (the size of the read-out at that concentration, not a potency): 74.1%
For compound 4 the middle estimate is 1.9 percentage points above the measured one, and the stated range covers the measured number.
By their numbers in this assay, from the lowest: compounds 4, 3, 1 and 2 (each within the scatter of the next).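

Shortening the chain to ethyl opens no real gap in this assay: the three new steps are a number 1.1 percentage points lower from compound 3 to compound 4 (within the scatter) and a number 4.2 percentage points lower from compound 2 to compound 4 (within the scatter) and a number 1.9 percentage points lower from compound 1 to compound 4 (within the scatter). The ethyl, propyl, butyl and allyl chains on this nitrogen therefore cannot be told apart on these numbers, and swapping vinyl for methyl at this place leaves the read-out inside the scatter. No further measurement is available to explain this. Still open, as far as these compounds go, is whether a much shorter or bulkier group, such as a bare amine or a cyclohexyl ring, would shift the number.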